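The source may hold more compounds than are shown below. What is called first, only, known or untested is meant among the compounds shown, and "the series" means these compounds.

Measured in a functional assay on HCT-116 cells (Homo sapiens) for cytotoxicity, read by MTT assay; on this read-out lower numbers stand for stronger inhibition and higher numbers for weaker inhibition:

- compound 1 `Cc1cc(O)c(C(=O)/C=C/c2ccc(F)cc2)c(=O)o1`: > 100000 nM (a limit of the assay)
- compound 2 `Cc1cc(O)c(C(=O)/C=C/c2cccc(Cl)c2)c(=O)o1`: 66400 nM
- compound 3 `Cc1cc(O)c(C(=O)/C=C/c2ccc(Cl)cc2)c(=O)o1`: 87400 nM

All three compounds are weak on these numbers. Compound 2 gives 66400 nM and compound 3 gives 87400 nM, so these two values lie within the usual scatter of each other. Compound 1 gives only a limit, > 100000 nM.

The next compound is compound 4 `Cc1cc(O)c(C(=O)/C=C/c2ccc(Cl)c(Cl)c2)c(=O)o1`. It differs from compound 3 as follows: chloro in place of hydrogen on an aromatic carbon. This is chloro in place of hydrogen on an aromatic carbon, ortho to a chloro group and meta to a large group.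

Among the measured compounds shown here, no measured step makes this exact change. The nearest is an at least 1.1-fold lower number from compound 1 to compound 3 (0.05 log units; that floor lies within the scatter), where chloro replaces fluoro on an aromatic carbon, and that step gives only a floor. For the measured compounds named here, nothing measured so far therefore shows a large effect from chloro on the aromatic ring, and compound 2 at 66400 nM stays in the same range as compound 3. In this assay a modest fall in the number is expected, close to the scatter and possibly within it.

The expected change is a 1.6-fold lower number from compound 3 to compound 4 (0.20 log units; within the scatter). For compound 4 the estimated value is 55000 nM, with an expected range from 25000 nM to 100000 nM.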

Compound 4, half-maximal inhibitory concentration: > 100000 nM
Compound 4 was reported as a limit; the forecaster's own chance of this, stated with the estimate: 15%; at least 1.8-fold (0.25 log units) between middle value and limit.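

The second chloro group, ortho to a chloro group and meta to a large group, gives no sign of stronger inhibition in this assay: the change reads as an at least 1.1-fold higher number from compound 3 to compound 4 (0.05 log units; that floor lies within the scatter). Counted from the other compound with a single chloro group, it reads as an at least 1.5-fold higher number from compound 2 to compound 4 (0.17 log units; that floor lies within the scatter). Until now the compounds shown had only one halogen on this ring, and these steps add that a second chloro group does not bring the number down, although neither floor shows a real rise beyond the scatter, and the true size of the change stays hidden behind the limit: the limit of > 100000 nM in this assay, at which 2 of the 4 values shown sit.

The compounds shown carry only fluoro and chloro groups on this ring, so it remains open whether a methoxy group, an amine or a carboxylic acid at the same place would move the number clear of the scatter. On these data alone, it also remains open how far compound 1 and compound 4 lie beyond the limit, and whether any change to this ring alone can give strong inhibition on the shared core.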